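This account rests on a few compounds, and the source may have more. Where it says the series, first, only, none or still open, it means among the compounds named here.

The measured compounds in an assay on isolated protein for binding affinity to cysteinyl leukotriene receptor 1 (Cavia porcellus); a higher number here means a weaker inhibitor, a lower number a stronger inhibitor:
compound 1 `c1cc(OCc2ccc3ccccc3n2)cc(-c2nn[nH]n2)c1`, 115 nM
compound 2 `c1ccc2nc(COc3ccc(Cc4nnn[nH]4)cc3)ccc2c1`, 275 nM
compound 3 `c1ccc2nc(COc3ccc(CCc4nnn[nH]4)cc3)ccc2c1`, 160 nM

Compound 2 has the highest number of the three; compound 3 lies closest to it and compound 1 furthest away. Compound 4 `c1ccc2nc(COc3ccc(SCCCc4nnn[nH]4)cc3)ccc2c1` differs from compound 2 in one place: a group of 9 heavy atoms (4 carbon, 4 nitrogen, 1 sulfur; one five-membered aromatic ring with 4 hetero atoms) in place of a group of 6 heavy atoms (2 carbon, 4 nitrogen; one five-membered aromatic ring with 4 hetero atoms), on an aromatic carbon. Within the data shown here, the one measured step that bears on this is the lengthening of the same chain from compound 2 to compound 3, which gave a 1.7-fold lower number from compound 2 to compound 3 (0.24 log units; within the scatter), a step within the scatter. The change to compound 4 extends that chain further and brings in a sulfur, so no step beyond the scatter is firmly expected in this assay, though a move toward a lower number seems plausible. The expected step is a 1.8-fold lower number from compound 2 to compound 4 (0.26 log units; within the scatter). Compound 4 is therefore estimated at 150 nM, with a range from 60 nM to 400 nM.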

Compound 4, inhibition constant: 31 nM
Beside the measured number, compound 4's estimate is 4.8-fold (0.68 log units) above it; the whole stated range lies above it.
By their numbers in this assay, from the lowest: compound 4; then compounds 1, 3 and 2 (each within the scatter of the next, the first and the last beyond it).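

In this assay the group of 9 heavy atoms, on an aromatic carbon para to a large group, gives a clear change (from an 8.9-fold lower number from compound 2 to compound 4 (0.95 log units; beyond the scatter) and a 5.2-fold lower number from compound 3 to compound 4 (0.71 log units; beyond the scatter)), both steps beyond the scatter. The shorter lengthening (from a 1.7-fold lower number from compound 2 to compound 3 (0.24 log units; within the scatter)) stayed within it, so this position can respond to the group placed there. Nothing at hand explains this step.

From the compounds shown here alone, whether the sulfur or the added chain length carries the step stays open. Also open, going by these compounds, is how an all-carbon chain of the same length, an ether oxygen in place of the sulfur, a longer chain or a carboxylic acid in place of the 1H-tetrazol-5-yl ring would compare.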